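Para substituent swaps on the shared core: fluoro to trifluoromethyl

The source may hold more compounds than are shown below. What is called first, only, known or untested is meant among the compounds shown, and "the series" means these compounds.

Measured compounds:
compound 1, `COc1ccc(Nc2cncc(N3CC4CC(C3)N4)c2)cc1`, 0.0598 nM
compound 2, `O=[N+]([O-])c1ccc(Nc2cncc(N3CC4CC(C3)N4)c2)cc1`, 0.0225 nM
compound 3, `Fc1ccc(Nc2cncc(N3CC4CC(C3)N4)c2)cc1`, 0.091 nM

In an assay on cell membranes for displacement of a labelled ligand from Neuronal acetylcholine receptor; alpha4/beta2 (Rattus norvegicus) (on this read-out lower numbers stand for stronger inhibition and higher numbers for weaker inhibition), compound 3 gives the highest of the three numbers. Its nearest neighbour is compound 1, which gives 0.0598 nM; the gap between them is a 1.5-fold higher number from compound 1 to compound 3 (0.18 log units; within the scatter). Compound 2, which gives 0.0225 nM, lies furthest away: a 4.0-fold higher number from compound 2 to compound 3 (0.61 log units; beyond the scatter). The one step beyond the scatter among these, a 2.7-fold lower number from compound 1 to compound 2 (0.42 log units; beyond the scatter), is modest.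

Compound 4, `FC(F)(F)c1ccc(Nc2cncc(N3CC4CC(C3)N4)c2)cc1`, is not yet measured. It differs from compound 3 in one place: trifluoromethyl in place of fluoro on an aromatic carbon.

Among the compounds with values here, all three measured steps concern the same place, a group on an aromatic carbon para to a large group, so they are the steps that bear on the change to compound 4. They span from within the scatter to a modest step, and the whole range of numbers across the three groups covers only a modest spread. A trifluoromethyl at that place is therefore expected to stay inside that spread; no step beyond the scatter is confidently expected in this assay, and the direction is open. The working estimate for compound 4 in this assay is 0.06 nM, between 0.02 nM and 0.18 nM, which means an expected step of a 1.5-fold lower number from compound 3 to compound 4 (0.18 log units; within the scatter).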

Compound 4, inhibition constant: 0.373 nM
Compound 4: the middle estimate sits 6.2-fold (0.79 log units) below what was measured; the measured number lies above the stated range.
By their numbers in this assay, from the lowest: compound 2; then compounds 1 and 3 (each within the scatter of the next); then compound 4.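

In this assay this place on the aromatic ring turns out to be less forgiving than the first three groups suggested: the change gives a 4.1-fold higher number from compound 3 to compound 4 (0.61 log units; beyond the scatter) and takes the series outside the narrow spread seen with methoxy, nitro and fluoro. Set against the other two groups, trifluoromethyl gives a 6.2-fold higher number from compound 1 to compound 4 (0.80 log units; beyond the scatter) and, at the far end of the order, a 17-fold higher number from compound 2 to compound 4 (1.22 log units; beyond the scatter) as the only large step among the compounds shown, so the choice of group at this place can matter substantially, and fluoro and trifluoromethyl cannot be treated as interchangeable here. The data shown offer no measurement that accounts for why trifluoromethyl stands apart from the other three groups.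

From the compounds shown here alone, with only four groups at this place, it remains open whether trifluoromethyl is an isolated case or marks a wider trend, and a nitrile, a carboxylic acid, an amine or a longer alkyl chain at the same carbon would help to separate those readings. Whether the same order of groups would hold at other carbons of the ring, or on a changed shared core, also stays unresolved.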